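The compounds below may be only part of what the source reports. "The series", "measured", "known", "first", "only" and "open" are said of these compounds alone.

Compound 1 `CN(CC1=CC[C@H]2C[C@@H]1C2(C)C)Cc1ccc(-c2ccccc2)cc1`: 3160 nM
Compound 2 `CN(CC1=CC[C@H]2C[C@@H]1C2(C)C)Cc1ccc(-c2ccc(C(F)(F)F)cc2)cc1`: > 316 nM (a limit, not a number)

In an assay on HEK293 cells for displacement of a labelled ligand from C-X-C chemokine receptor type 3 (Homo sapiens) (a lower number here means a stronger inhibitor, a higher number a weaker inhibitor), compound 1 gives 3160 nM, and this is the only value among the two shown that stands as a number. For compound 2 the assay reports only a limit, > 316 nM. That value is the limit of > 316 nM in this assay, at which 1 of the 2 values shown sits. Within the data shown here, the single measured step, a step that the limit leaves unreadable from compound 1 to compound 2, therefore cannot be sized. Compound 3 `CN(CC1=CC[C@H]2C[C@@H]1C2(C)C)Cc1ccc(-c2cccc([N+](=O)[O-])c2)cc1` differs from compound 1 in one place: nitro in place of hydrogen on an aromatic carbon. Among the measured compounds shown here, no measured step shows what a nitro group at this place does to binding, and the one change made on the same ring, the trifluoromethyl of compound 2, ends in an unreadable step. Compound 3 is therefore expected to stay near compound 1, with an estimated step of a 1.1-fold lower number from compound 1 to compound 3 (0.02 log units; within the scatter) that does not exceed the scatter. The estimate for compound 3 is 3000 nM, within 800 nM to 12000 nM.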

Compound 3, inhibition constant: 2000 nM
Compound 3: middle estimate off by 1.5-fold (0.18 log units), on the high side, and the stated range covers the measured number.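

In this assay, among these compounds, the only readable step on this ring is a 1.6-fold lower number from compound 1 to compound 3 (0.20 log units; within the scatter), so the change from phenyl to 3-nitrophenyl, with nitro on an aromatic carbon meta to a large group, is tolerated without a shift beyond the usual scatter. Compound 2 is reported only as a limit, so its step cannot be read and cannot be set against this one. Nothing measured here gives a cause for the step from hydrogen to nitro.

Still open, on these data alone, is whether another group at this place, such as an amine or a carboxylic acid, would move the number in this assay beyond the scatter. Also open, as far as these compounds go, is whether nitro on another carbon of the same ring would give a value that stays within the scatter of compound 1.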